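Methoxy added to the compound 2 acid

This account rests on a few compounds, and the source may have more. Where it says the series, first, only, none or still open, it means among the compounds named here.

Among the measured compounds shown here, in a functional assay on a cell-free system (Platelet, plasma, Oryctolagus cuniculus) for inhibition, with a stated time of 5 min (a higher number here means a weaker inhibitor, a lower number a stronger inhibitor), compound 2 `Cc1nc(C)c(COc2ccccc2/C=C/C(=O)O)nc1C` gives 54000 nM as the only true number so far. Compound 1 `CCOC(=O)/C=C/c1cccc(OC)c1OCc1nc(C)c(C)nc1C` stands at > 2000000 nM which is a limit and not a number. Compound 3 `COc1cccc(/C=C/C(=O)O)c1OCc1nc(C)c(C)nc1C` differs from compound 2 by one change: methoxy in place of hydrogen on an aromatic carbon with methoxy in place of hydrogen on an aromatic carbon. For the measured compounds named here, no measured pair isolates this change. A small shift towards stronger inhibition is expected in this assay and may not exceed the scatter. The expected step is a 1.4-fold lower number from compound 2 to compound 3 (0.13 log units; within the scatter) in this estimate. Compound 3 is estimated at 40000 nM with an expected range of 12000 nM to 150000 nM for repeat measurements.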

Compound 3, half-maximal inhibitory concentration: 522000 nM
Estimate against measurement, compound 3: 13-fold (1.12 log units) below, and the stated range ends below it.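

In this assay, methoxy in place of hydrogen at this position, ortho to a large group and meta to a 2-carboxyethenyl group, weakens inhibition, with a 9.7-fold higher number from compound 2 to compound 3 (0.99 log units; beyond the scatter). With the methoxy kept, hydrogen in place of ethyl on an oxygen next to a carbonyl group gives an at least 3.8-fold lower number from compound 1 to compound 3 (0.58 log units; beyond the scatter), so the free acid retains measurable inhibition. The value of compound 1 is a limit and not a number, so this step has only a bound: the limit of > 2000000 nM in this assay, at which 1 of the 3 values shown sits.

Going by these compounds, whether hydroxy or fluoro at this position would shift the number as methoxy does remains open. Also open, on these data alone, is whether an ethoxy or a longer chain there would move it further.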